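Nitro in place of bromo on compound 3

The source may report more compounds than this note shows. Statements on the series, on what has been measured and on what is new or still open speak of the compounds shown alone.

In a functional assay on HeLa cells (Homo sapiens) for antiproliferative activity, read by MTT assay, with a stated time of 48 h (a lower number here means a stronger inhibitor of growth, a higher number a weaker inhibitor of growth), compound 1 (`Cc1cc2c(c(=O)n1C)C(c1ccc(N(C)C)c(Br)c1)C(C#N)=C(N)O2`) gives 330 nM, compound 2 (`Cc1cc2c(c(=O)n1C)C(c1ccc(F)c(Br)c1)C(C#N)=C(N)O2`) gives 6400 nM and compound 3 (`Cc1cc2c(c(=O)n1C)C(c1cccc(Br)c1)C(C#N)=C(N)O2`) gives 6500 nM. Compound 3 sits with compound 2 at the high end of these numbers, and a 1.0-fold higher number from compound 2 to compound 3 (0.01 log units; within the scatter) lies within the scatter. Compound 1 stands apart, with large steps in a 19-fold higher number from compound 1 to compound 2 (1.29 log units; beyond the scatter) and a 20-fold higher number from compound 1 to compound 3 (1.29 log units; beyond the scatter).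

Compound 4 (`Cc1cc2c(c(=O)n1C)C(c1cccc([N+](=O)[O-])c1)C(C#N)=C(N)O2`) has nitro in place of bromo on an aromatic carbon, meta to a large group: nitro in place of bromo on an aromatic carbon. Within the data shown here, all three measured compounds keep the bromo, so no measured step tests its replacement. Both large steps involve loss of dimethylamino, which neither compound 3 nor compound 4 carries. The closest guide is the small 1.0-fold higher number from compound 2 to compound 3 (0.01 log units; within the scatter), so no step beyond the scatter is expected in this assay, though with wide uncertainty. The expected change is a 1.3-fold lower number from compound 3 to compound 4 (0.11 log units; within the scatter). Compound 4 is estimated at 5000 nM, with an expected range of 1500 nM to 16000 nM.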

Compound 4, concentration for 50% growth inhibition: 35000 nM
Compound 4: middle estimate off by 7.0-fold (0.85 log units), on the low side, outside the stated range (above it).
By their numbers in this assay, from the lowest: compound 1; then compounds 2 and 3 (each within the scatter of the next); then compound 4.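

In this assay, nitro in place of bromo on the aromatic carbon meta to a large group gives a 5.4-fold higher number from compound 3 to compound 4 (0.73 log units; beyond the scatter). Among these compounds, this shows that the group at this position affects the read-out, whereas the earlier steps all kept the bromo and varied only dimethylamino, fluoro or hydrogen. The step is modest but beyond the scatter, and it runs towards weaker growth inhibition; no measurement in hand bears on its cause.

With only bromo and nitro shown at this position, it remains open whether the shift tracks the group leaving or the group entering, and an amine or a chloro group on the same carbon would help separate the two. Also open, going by these compounds, is whether nitro in place of bromo costs the same when dimethylamino is present, as in compound 1.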